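A few compounds are considered here, and "the series" means these few. Any claim that something is new, unique, unknown or untested is made for them only; others in the source may bear on it.

Compound 1 `Cc1ccc(C(=O)NC(=N)Nc2ccc(C(C)C)cc2)cc1` gives 1950 nM in an assay on CHO cells for inhibition of sodium channel protein type 2 subunit alpha (Homo sapiens); on this read-out lower numbers stand for stronger inhibition and higher numbers for weaker inhibition.
Compound 2 `N=C(NCCCCc1ccccc1)NC(=O)c1cccc(Cl)c1Cl` gives 1480 nM in this assay.
Compound 3 `CCCCOc1ccc(C(=O)NC(=N)NCCCCc2ccccc2)cc1` gives 630 nM in this assay.

Among these three numbers, compound 2 stands second highest. Its nearest neighbour is compound 1, and the gap between them is within the usual scatter of this assay, so the two cannot be ranked against each other. Compound 3 lies furthest away, with a lower number, and that gap does lie beyond the scatter.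

Compound 4 `N=C(NCCCCc1ccccc1)NC(=O)c1ccco1` is not yet measured. It differs from compound 2 in one place: furan-2-yl in place of 2,3-dichlorophenyl on a carbonyl carbon. Among the measured compounds there is no pair that shows this exchange on its own, so the expectation for compound 4 rests only on the general picture, in which every measured number sits in a narrow band. A group with fewer heavy atoms and one fewer ring carbon enters where the dichlorinated ring leaves. The step expected from compound 2 to compound 4 is a rise in the number, that is, weaker inhibition, of a size just beyond the scatter: a 2.4-fold higher number from compound 2 to compound 4 (0.37 log units; beyond the scatter). For compound 4 the estimate in this assay is 3500 nM, with a range from 1400 nM to 9000 nM.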

Compound 4, half-maximal inhibitory concentration: 13800 nM
Beside the measured number, compound 4's estimate is 3.9-fold (0.60 log units) below it; measured number outside the range, above it.
By their numbers in this assay, from the lowest: compound 3; then compounds 2 and 1 (each within the scatter of the next); then compound 4.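

In this assay, the group on the carbonyl carbon turns out to matter a great deal: with the rest of the molecule unchanged, furan-2-yl in place of 2,3-dichlorophenyl gives a 9.3-fold higher number from compound 2 to compound 4 (0.97 log units; beyond the scatter). Going by these compounds alone, the earlier compounds offered no pair differing in one place, so this is the first view of what a single exchange at this position can do, and it is a clear move towards weaker inhibition. The exchange alters several things at once, however: the chlorine atoms leave, a six-membered ring of carbon only gives way to a five-membered ring with a hetero atom, and a hydrogen-bond acceptor enters, and no measurement here links the step to any one of these differences.

From the compounds shown here alone, it stays open which of these differences carries the step: an unsubstituted phenyl, a single chlorophenyl or a thiophen-2-yl group on the same carbonyl carbon would begin to separate them. The compounds shown also leave open how a saturated ring such as cyclohexyl would behave at this place.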